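Fluoro to methyl on the benzyl end of compound 1

A few compounds are considered here, and "the series" means these few. Any claim that something is new, unique, unknown or untested is made for them only; others in the source may bear on it.

In a functional assay on DU-145 cells (Homo sapiens) for inhibition, read by trypan blue exclusion, with a stated time of 96 h (a lower number here means a stronger inhibitor of growth, a higher number a weaker inhibitor of growth), compound 1 `CSc1ccc(/C=C(\C(=O)c2ccc(Br)cc2)S(=O)(=O)Cc2ccc(F)cc2)cc1` gives 50000 nM, the higher of the two numeric values, while compound 2 `Cc1ccc(C)c(/C=C(\C(=O)c2ccc(Br)cc2)S(=O)(=O)Cc2ccc(F)cc2)c1` gives 1000 nM. Compound 3 `O=C(/C(=C\c1cc([N+](=O)[O-])ccc1F)S(=O)(=O)Cc1ccc(F)cc1)c1ccc(Br)cc1` gives > 100000 nM, which is a limit of the assay and not a number. Compound 4 `CSc1ccc(/C=C(\C(=O)c2ccc(Br)cc2)S(=O)(=O)Cc2ccc(C)cc2)cc1` differs from compound 1 by methyl in place of fluoro on an aromatic carbon. Within the data shown here, the large steps, a 50-fold lower number from compound 1 to compound 2 (1.70 log units; beyond the scatter) and an at least 100-fold higher number from compound 2 to compound 3 (2.00 log units; beyond the scatter), exchange a different group, and no measured step touches the fluoro. They therefore set no size for this change, and no step beyond the scatter is expected in this assay. The expected step is a 1.3-fold lower number from compound 1 to compound 4 (0.10 log units; within the scatter). Compound 4 is estimated at 40000 nM, with an expected range of 10000 nM to 100000 nM.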

Compound 4, concentration for 50% growth inhibition: 10000 nM
Estimate against measurement, compound 4: 4.0-fold (0.60 log units) above, and the stated range covers the measured number.
By their numbers in this assay, from the lowest: compound 2; then compound 4; then compound 1. At a limit, above all of these: compound 3.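

Changing the benzyl end of the core registers in this assay: 4-methylbenzyl in place of 4-fluorobenzyl gives a 5.0-fold lower number from compound 1 to compound 4 (0.70 log units; beyond the scatter). Among these compounds, this aromatic carbon, para to a large group, therefore matters to growth inhibition, although this step is modest and the large steps so far came from exchanging the other aryl group. Nothing shown here bears on the cause of this step.

From the compounds shown here alone, whether the same exchange holds with the 2,5-dimethylphenyl group of compound 2 stays open. So does the outcome with a methoxy group, a chloro group or an amine at this carbon.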